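The compounds below may be only part of what the source reports. "The series", "measured", "known", "first", "only" and "open" are said of these compounds alone.

Compound 1 `CC(C)(C)OC(=O)NC1CCCN(C(=O)CN2CN(c3ccccc3)C3(CCN(C(=O)c4ccc(C(C)(C)C)cc4)CC3)C2=O)C1` is the starting point of this comparison. Going by the values given here, in an assay on HEK293 cells for displacement of a labelled ligand from NPC1-like intracellular cholesterol transporter 1 (Homo sapiens) (on this read-out higher numbers stand for weaker inhibition and lower numbers for stronger inhibition), compound 1 gives 4200 nM, the lower of the two numbers so far, and its nearest neighbour is compound 2 `CC(C)(C)c1ccc(C(=O)N2CCC3(CC2)C(=O)N(CC(=O)N2CCCC(CO)C2)CN3c2ccccc2)cc1`, which in this assay gives 8200 nM; the step of a 2.0-fold higher number from compound 1 to compound 2 (0.29 log units; within the scatter) therefore stays within the scatter. Compound 3 `CC(C)(C)OC(=O)NC1CCCN(C(=O)CN2CN(c3ccccc3)C3(CCN(C(=O)c4ccc(C5CCCCC5)cc4)CC3)C2=O)C1` differs from compound 1 in one place only: cyclohexyl in place of tert-butyl on an aromatic carbon. Among the compounds with values here, the single measured step alters a group on a saturated ring carbon and leaves the aromatic carbon untouched, so it does not bear on this change, and no measured pair tests cyclohexyl against tert-butyl. With nothing to point either way, the expected step in this assay is no change at the digits printed from compound 1 to compound 3 (within the scatter), which is none beyond the scatter. Compound 3 is accordingly estimated at 4200 nM, with a range from 1400 nM to 12600 nM.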

Compound 3, half-maximal inhibitory concentration: 4400 nM
Estimate against measurement, compound 3: 1.0-fold (0.02 log units) below, within the range that was stated.
By their numbers in this assay, from the lowest: compounds 1, 3 and 2 (each within the scatter of the next).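

In this assay, going by these compounds alone, cyclohexyl in place of tert-butyl gives a 1.0-fold higher number from compound 1 to compound 3 (0.02 log units; within the scatter), the first measured step at this aromatic carbon, para to a large group. At this position, then, the group with 6 heavy atoms and a six-membered non-aromatic ring takes the place of the group with 4 heavy atoms and no ring without a step beyond the scatter, which holds for this one pair of groups on the core of compound 1. Nothing given here offers an explanation for this result. From the compounds shown here alone, it remains open whether an amine, a carboxylic acid or a methoxy group at this aromatic carbon would give a step beyond the scatter. Going by these compounds, it is also open whether cyclohexyl would read the same way with hydroxymethyl on the saturated ring, as in compound 2.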